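The source may hold more compounds than are shown below. What is called first, only, known or untested is meant among the compounds shown, and "the series" means these compounds.

Measured compounds in a functional assay on MCF7 cells (Homo sapiens) for antiproliferative activity; a lower number here means a stronger inhibitor, a higher number a weaker inhibitor:
Compound 1 `C#CCCCn1c(Cc2cc(OC)c(OC)c(OC)c2)nc2c(N)ncnc21` gives 24000 nM.
Compound 2 `COc1cc(Cc2nc3c(N)ncnc3n2CC2CC2)cc(OC)c1OC` gives 75900 nM.
Compound 3 `COc1cc(Cc2nc3c(N)ncnc3n2CC(OC)OC)cc(OC)c1OC` gives 72400 nM.

Compound 3 stands second highest of the three numbers. Its nearest neighbour is compound 2, and the two differ by a 1.0-fold lower number from compound 2 to compound 3 (0.02 log units; within the scatter), which is within the scatter, so no order between them can be read. The furthest is compound 1, from which the step is a 3.0-fold higher number from compound 1 to compound 3 (0.48 log units; beyond the scatter).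

Compound 4 `C=CCCn1c(Cc2cc(OC)c(OC)c(OC)c2)nc2c(N)ncnc21` carries the change (allyl in place of dimethoxymethyl on a saturated chain carbon bound to an aromatic nitrogen). Among the compounds with values here, two measured steps bear on it. The step of a 3.0-fold higher number from compound 1 to compound 3 (0.48 log units; beyond the scatter) shows that replacing but-3-yn-1-yl with dimethoxymethyl weakened the inhibitor modestly, and the step of a 3.2-fold higher number from compound 1 to compound 2 (0.50 log units; beyond the scatter) shows much the same for cyclopropyl. Allyl is an unsaturated chain, closer in kind to but-3-yn-1-yl than either of those groups, so the reverse direction is expected: a modest drop in this assay, back toward compound 1 but not necessarily all the way.

Compound 4 is therefore expected to give 35000 nM, within a range of 15000 nM to 90000 nM, which corresponds to an estimated step of a 2.1-fold lower number from compound 3 to compound 4 (0.32 log units; beyond the scatter).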

Compound 4, half-maximal inhibitory concentration: 40700 nM
Beside the measured number, compound 4's estimate is 1.2-fold (0.07 log units) below it; measured number inside the range.
By their numbers in this assay, from the lowest: compounds 1, 4, 3 and 2 (each within the scatter of the next, the first and the last beyond it).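

In this assay, the allyl group of compound 4 cannot be told apart from any of the three groups it is set against, since each step lies within the scatter (a 1.8-fold lower number from compound 3 to compound 4 (0.25 log units; within the scatter); a 1.9-fold lower number from compound 2 to compound 4 (0.27 log units; within the scatter); a 1.7-fold higher number from compound 1 to compound 4 (0.23 log units; within the scatter)). The earlier compounds shown here had separated compound 1 from compound 2 and compound 3, but compound 4 joins neither side clearly, so the change from propargyl to vinyl at the chain end shows no readable effect on its own. No measurement offered here explains these results.

Still open, on these data alone, is whether an amine or a carboxylic acid on this saturated chain carbon would give a number clearly apart from these. Also open, as far as these compounds go, is whether a longer chain ending in a triple bond would do so.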